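Three benzyl groups on a shared core, and a fourth

The source may report more compounds than this note shows. Statements on the series, on what has been measured and on what is new or still open speak of the compounds shown alone.

Three compounds share one core and differ only in the group on a saturated chain carbon bound to an aromatic nitrogen. Compound 1 `CCCn1c(=O)c2nc(-c3cnn(Cc4cc(Cl)ccc4Cl)c3)[nH]c2n(CCC)c1=O` carries a 2,5-dichlorophenyl there; in an in vitro assay on HEK293 cells for displacement of a labelled ligand from adenosine receptor A2b (Homo sapiens) (a higher number here means a weaker inhibitor, a lower number a stronger inhibitor), compound 1 gives 29 nM. Compound 2 `CCCn1c(=O)c2nc(-c3cnn(Cc4ccc(F)cc4F)c3)[nH]c2n(CCC)c1=O` carries a 2,4-difluorophenyl, and in this assay compound 2 gives 700 nM, the weakest of the three, since a 24-fold higher number from compound 1 to compound 2 (1.38 log units; beyond the scatter). Compound 3 `CCCn1c(=O)c2nc(-c3cnn(Cc4ccccc4C(F)(F)F)c3)[nH]c2n(CCC)c1=O` carries a 2-(trifluoromethyl)phenyl, and in this assay compound 3 gives 37 nM. Compound 3 sits with compound 1, as a 1.3-fold higher number from compound 1 to compound 3 (0.11 log units; within the scatter), and well apart from compound 2, as a 19-fold lower number from compound 2 to compound 3 (1.28 log units; beyond the scatter).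

Compound 4 `CCCn1c(=O)c2nc(-c3cnn(Cc4c(F)cc(F)cc4F)c3)[nH]c2n(CCC)c1=O` is a new member: 2,4,6-trifluorophenyl in place of 2-(trifluoromethyl)phenyl on a saturated chain carbon bound to an aromatic nitrogen. Compound 4 thus carries a fluorine-only phenyl like compound 2, which gave the weak number, rather than the groups of compounds 1 and 3; no ring with three fluorines has been measured, so the step is uncertain. The expectation for compound 4 is a clearly higher number, an 8.1-fold higher number from compound 3 to compound 4 (0.91 log units; beyond the scatter), leaning toward compound 2 because a 19-fold lower number from compound 2 to compound 3 (1.28 log units; beyond the scatter) was large. Compound 4 is therefore estimated at 300 nM, with a range from 60 nM to 1500 nM.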

Compound 4, inhibition constant: 650 nM
The estimate for compound 4 lay 2.2-fold (0.34 log units) below the measured number; the range from low to high includes it.
By their numbers in this assay, from the lowest: compounds 1 and 3 (each within the scatter of the next); then compounds 4 and 2 (each within the scatter of the next).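

In this assay, 2,4,6-trifluorophenyl in place of 2-(trifluoromethyl)phenyl gives an 18-fold higher number from compound 3 to compound 4 (1.24 log units; beyond the scatter) and, set against the 2,5-dichlorophenyl group, gives a 22-fold higher number from compound 1 to compound 4 (1.35 log units; beyond the scatter), so at this position a second ring carrying only fluorines ends up far from the two compounds with the lower numbers. The step that adds one fluoro in place of hydrogen on an aromatic carbon gives a 1.1-fold lower number from compound 2 to compound 4 (0.03 log units; within the scatter), so the two fluorine-only rings cannot be told apart here, even though they carry different numbers of fluorines. Nothing available gives a measured reason for the wide gap between these two rings and the groups of compounds 1 and 3.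

The compounds shown leave open which feature of the 2,5-dichlorophenyl and 2-(trifluoromethyl)phenyl groups goes with the lower numbers, since each ring differs from the fluorine-only rings in more than one respect. A phenyl ring with a single chlorine, or one carrying a methoxy group, an amine or a carboxylic acid, would show how far this trend extends beyond halogen and trifluoromethyl groups.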